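Phenylbenzofuran hydroxamate to hydroxyurea: one replacement on the carbonyl

The source may hold more compounds than are shown below. What is called first, only, known or untested is meant among the compounds shown, and "the series" means these compounds.

Three compounds have numbers in an assay on RBL cells for inhibition of Polyunsaturated fatty acid 5-lipoxygenase (Rattus norvegicus); a higher number here means a weaker inhibitor, a lower number a stronger inhibitor. Compound 1 `CCCCCCCCCCc1cc2cc(C(C)N(O)C(C)=O)ccc2o1` gives 410 nM in this assay. Compound 2 `COc1ccc2cc(-c3cc4cc(C(C)N(O)C(C)=O)ccc4o3)ccc2c1` gives 120 nM in this assay. Compound 3 `COc1cccc(OC)c1C(=O)N(O)C(C)c1ccc2oc(-c3ccccc3)cc2c1` gives 3000 nM in this assay, the highest number of the three; the gap from compound 3 to compound 1 and the larger gap from compound 3 to compound 2 both lie beyond the scatter. Going by the values given here, compounds 1 and 2 carry a shared core that differs from that of compound 3 in more than one place, so no single step between measured compounds can be read off here.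

Compound 4 `CC(c1ccc2oc(-c3ccccc3)cc2c1)N(O)C(N)=O` is the next compound to be measured in this assay. It differs from compound 3 by amino in place of 2,6-dimethoxyphenyl on a carbonyl carbon. Among the compounds with values here, the 2,6-dimethoxyphenyl group of compound 3 goes with the weakest number in the set, and its removal is the only change made.

Expectation: the step from compound 3 to compound 4 in this assay is estimated to be downward by a 20-fold lower number from compound 3 to compound 4 (1.30 log units; beyond the scatter), beyond the scatter. Compound 4 is expected to give about 150 nM in this assay, with a range from 40 nM to 600 nM.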

Compound 4, half-maximal inhibitory concentration: 410 nM
The estimate for compound 4 lay 2.7-fold (0.44 log units) below the measured number, within the range that was stated.
By their numbers in this assay, from the lowest: compound 2; then compounds 1 and 4 (each within the scatter of the next); then compound 3.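

In this assay, this first single-place comparison in the series shows that the value responds to the group on the carbonyl carbon: amino in place of 2,6-dimethoxyphenyl gives a 7.3-fold lower number from compound 3 to compound 4 (0.86 log units; beyond the scatter), a modest step but one beyond the scatter. The 2,6-dimethoxyphenyl group, with its aromatic ring, is therefore not required for inhibition here, since compound 4 reaches 410 nM with one nitrogen in that place. Nothing on hand explains the step, and the loss of the aromatic ring cannot be separated from the arrival of the amino group with its hydrogen-bond donor.

From the compounds shown here alone, it remains open whether an unsubstituted phenyl, a methylamino or a dimethylamino group on the same carbonyl carbon would give a number closer to that of compound 3 or compound 4, which would help separate the two parts of this replacement. Also open, going by these compounds, is whether amino in this place would give a step of similar size on the shared core of compounds 1 and 2.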